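Bromo to 2,6-dimethylphenyl: working notes on the series

This account rests on a few compounds, and the source may have more. Where it says the series, first, only, none or still open, it means among the compounds named here.

compound 1 `CCOC(=O)c1c(-c2cccc(OC(F)(F)F)c2)[nH]c2cc(OC)c(F)cc2c1=O`, limit > 22000 nM
compound 2 `CCOC(=O)c1c(-c2cccc(Cl)c2)[nH]c2cc(OC)c(F)cc2c1=O`, limit > 22000 nM
compound 3 `CCOC(=O)c1c(-c2cccc(Br)c2)[nH]c2cc(OC)c(F)cc2c1=O`, limit > 22000 nM

All three measured compounds are reported in an ADME assay on HEK293 cells (Homo sapiens) for cytotoxicity, read by luminescence, with a stated time of 72 h (on this read-out higher numbers stand for an effect only at larger amounts of compound and lower numbers for an effect already at smaller amounts), as limits and not as numbers. Compound 3 gives the limit > 22000 nM. Within the data shown here, the series so far rests on (the limit of > 22000 nM in this assay, at which 3 of the 3 values shown sit).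

Compound 4 `CCOC(=O)c1c(-c2cccc(-c3c(C)cccc3C)c2)[nH]c2cc(OC)c(F)cc2c1=O` carries 2,6-dimethylphenyl in place of bromo on an aromatic carbon.

The closest measured steps are a step that the two limits leave unreadable from compound 1 to compound 3 and a step that the two limits leave unreadable from compound 2 to compound 3. The remaining one is a step that the two limits leave unreadable from compound 1 to compound 2. None of these gives a size or a direction, and none brings a new ring into the structure.

With no measured shift to carry over, compound 4 is expected to stay close to the limit of compound 3 at > 22000 nM in this assay, and a reported limit is the likeliest outcome. The expected change is a number no higher from compound 3 to compound 4 (the limit leaves the size open), with no firm direction. For compound 4 the estimate is 22000 nM, with an expected range from 9000 nM to 45000 nM.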

Compound 4, half-maximal effective concentration: > 22000 nM
Compound 4: no number, only a limit; the forecaster's own chance of this, stated with the estimate: 70%; the middle value lies on the limit itself.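

Among these compounds, compound 4, like compound 1, compound 2 and compound 3, is reported only as a limit in this assay, so no step between compound 4 and any of them can be read: the limit of > 22000 nM in this assay, at which 4 of the 4 values shown sit. The compounds shown leave open at what concentration any of them would show an effect in this assay.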